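The source may report more compounds than this note shows. Statements on the series, on what has been measured and on what is new or still open speak of the compounds shown alone.

Measured in a functional assay on the whole organism (strain Sprague-Dawley) for inhibition, with Rattus norvegicus as the target, with a stated time of 10 min; a lower number here means that less compound is needed, a higher number that more compound is needed for the effect:
compound 1 `O=C(O)c1cnc(-c2ccc(Cl)cc2)[nH]c1=O`: 5 mg/kg
compound 2 `CCOC(=O)c1cnc(-c2ccc(Cl)cc2)[nH]c1=O`: > 30 mg/kg

Compound 2 stands at > 30 mg/kg, which is a limit of this assay and not a number.

Compound 3 `CCOC(=O)c1cnc(-c2ccc(OC)cc2)[nH]c1=O` keeps the ethyl of compound 2 and differs elsewhere: methoxy in place of chloro on an aromatic carbon. In short, methoxy takes the place of chloro on an aromatic carbon.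

Going by the values given here, the only measured step is an at least 6.0-fold higher number from compound 1 to compound 2 (0.77 log units; beyond the scatter), and it concerns the ethyl, not the place of this change. Among the compounds with values here, no measured step covers methoxy in place of chloro, so neither size nor direction has direct support. Compound 3 retains the ethyl of that step, and a further reading at the limit is likely. No step beyond the scatter is expected, and the expected step is a number no higher from compound 2 to compound 3 (the limit leaves the size open). The estimate for compound 3 is 30 mg/kg, with an expected range of 12 mg/kg to 60 mg/kg.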

Compound 3, dose for 50% inhibition: 30 mg/kg
For compound 3 middle estimate and measured number coincide at the digits printed; the measured number falls inside the stated range.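

Going by these compounds alone, on an aromatic carbon para to a large group, methoxy in place of chloro gives a number no higher from compound 2 to compound 3 (the limit leaves the size open) in this assay, the first reading on this position. Compound 2 has > 30 mg/kg, which is a limit of the assay and not a number. Compound 3 gives 30 mg/kg, so a compound carrying the ethyl can give a readable value here, but the size of the change remains unreadable: the limit of > 30 mg/kg in this assay, at which 1 of the 3 values shown sits.

Still open, from the compounds shown here alone, is how methoxy in place of chloro reads with hydrogen instead of the ethyl, as in compound 1, where a pair differing in this one place would give a step with a readable size. Also open, going by these compounds, is how an amine or a longer alkoxy chain at this position reads in this assay.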